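The compounds below may be only part of what the source reports. "The series", "measured", "known", "first", "only" and "open" are said of these compounds alone.

Compound 1 `CC(C)(C)OC(=O)N1CCC[C@@H]1C(=O)N1CCC(NS(=O)(=O)c2cc(S(=O)(=O)c3ccccc3)ccc2C(F)(F)F)CC1` gives 210 nM in a functional assay on U2OS cells for antagonist activity at proto-oncogene Wnt-3 (Homo sapiens), read by a luciferase reporter, with a stated time of 18 h; a lower number here means that less compound is needed, a higher number that more compound is needed for the effect; compound 2 `O=C([C@@H]1CCCN1C(=O)c1ccncc1)N1CCC(NS(=O)(=O)c2cc(S(=O)(=O)c3ccccc3)ccc2C(F)(F)F)CC1` gives 350 nM in this assay.

Compound 2 holds the higher of the two numbers, yet its gap to compound 1 lies within the scatter, so neither compound can be called the more potent. Compound 3 `CCNC(=O)N1CCC[C@H]1C(=O)N1CCC(NS(=O)(=O)c2cc(S(=O)(=O)c3ccccc3)ccc2C(F)(F)F)CC1` differs from compound 2 by ethylamino in place of pyridin-4-yl on a carbonyl carbon. Among the compounds with values here, no measured pair shows this change. Since compound 1 and compound 2 carry different groups on that same carbonyl carbon and still sit within the scatter of each other, the step of a 1.1-fold higher number from compound 2 to compound 3 (0.06 log units; within the scatter) is expected to stay small, perhaps slightly upward. Compound 3 is estimated at 400 nM, in the range 150 nM to 1100 nM.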

Compound 3, half-maximal effective concentration: 90 nM
Compound 3: the middle estimate sits 4.4-fold (0.65 log units) above what was measured, outside the stated range (below it).
By their numbers in this assay, from the lowest: compound 3; then compounds 1 and 2 (each within the scatter of the next).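

Compound 1 and compound 2 sat within the scatter of each other, so they gave no sign that the group on this carbonyl carbon matters; ethylamino in place of pyridin-4-yl now shows that it does (a 3.9-fold lower number from compound 2 to compound 3 (0.59 log units; beyond the scatter)). The ethylcarbamoyl group also gives a lower number than the tert-butoxycarbonyl group (a 2.3-fold lower number from compound 1 to compound 3 (0.37 log units; beyond the scatter)), and both steps lie beyond the scatter. Nothing at hand gives a reason for either step.

As far as these compounds go, it stays open whether the lower number follows the hydrogen-bond donor of ethylamino or the absence of a ring. Dimethylamino or a longer propylamino chain on the same carbonyl carbon would bear on this.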